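This account rests on a few compounds, and the source may have more. Where it says the series, first, only, none or still open, it means among the compounds named here.

Measured in an ADME assay on HEp-2 cells (Homo sapiens) for cytotoxicity; a lower number here means that less compound is tolerated, a higher number that more compound is tolerated:
compound 1 `N#CCCCn1c(Cn2c(=O)[nH]c3ccncc32)nc2ccccc21`; compound 1 gives 264000 nM.
compound 2 `N#CCCCn1c(Cn2c(=O)n(C3CCC3)c3ccncc32)nc2ccccc21`; compound 2 gives only a limit, > 258000 nM.
compound 3 `CS(=O)(=O)CCCn1c(Cn2c(=O)n(C3CC3)c3ccncc32)nc2ccccc21`; compound 3 gives > 230000 nM; > 227000 nM (2 entries).

Compound 2 stands at a limit in this assay, with one further entry that carries no single number. The step that the limit leaves unreadable from compound 1 to compound 2 is left unreadable by that limit. Compound 4 `CS(=O)(=O)CCCn1c(Cn2c(=O)n(C3CCC3)c3ccncc32)nc2ccccc21` differs from compound 2 by methylsulfonyl in place of cyano on a saturated chain carbon, three bonds along the chain from an aromatic nitrogen. Going by the values given here, no measured step covers this change directly; the nearest evidence is the several entries of compound 3 in this assay, > 230000 nM; > 227000 nM (2 entries) and (the limit of > 258000 nM in this assay, at which 1 of the 3 values shown sits), all of them limits. In this assay no step beyond the scatter is therefore expected, and the change from compound 2 to compound 4 is estimated as an at least 1.0-fold lower number from compound 2 to compound 4 (0.01 log units; that floor lies within the scatter). Compound 4 is expected to give 250000 nM, within 150000 nM to 500000 nM, most likely again reported only as a limit.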

Compound 4, half-maximal cytotoxic concentration: > 227000 nM
Compound 4: a limit, no number; the forecaster's own chance of this, stated with the estimate: 85%; the middle value lies beyond the limit too.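

In this assay compound 2 and compound 4 both stand only at limits, so no step can be read between them. The compounds shown leave open whether methylsulfonyl in place of cyano changes the tolerated concentration at all.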